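The source may hold more compounds than are shown below. What is called first, only, known or untested is meant among the compounds shown, and "the series" means these compounds.

Measured compounds in an ADME assay on MCF-10A cells (Homo sapiens) for cytotoxicity, read by sulforhodamine B assay, with a stated time of 48 h; a lower number here means a stronger inhibitor of growth, a higher number a weaker inhibitor of growth:
compound 1 `O=C1C(=O)N(CN2CCN(c3ccnc4cc(Cl)ccc34)CC2)c2cc(Br)ccc21` gives 18000 nM
compound 2 `NC(=S)N/N=C1/C(=O)N(CN2CCN(c3ccnc4cc(Cl)ccc34)CC2)c2cccc(Br)c21` gives 29400 nM
compound 3 `NC(=S)N/N=C1/C(=O)N(CN2CCN(c3ccnc4cc(Cl)ccc34)CC2)c2cc(Cl)ccc21` gives 64600 nM

Compound 3 has the highest number of the three in this assay. Its nearest neighbour is compound 2, whose number is lower by a margin beyond the scatter; compound 1 lies further off, also beyond the scatter. No two of the three differ in a single place, so none of these gaps is tied to one structural change.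

Compound 4 `NC(=S)N/N=C1/C(=O)N(CN2CCN(c3ccnc4cc(Cl)ccc34)CC2)c2ccccc21` is the unmeasured member. From compound 3 to compound 4 the change is hydrogen in place of chloro on an aromatic carbon. Among the compounds with values here, no measured pair shows this step, so the size it produces in this assay is not known from the series. The expectation is a modest move, if any, toward a higher number, and it may well fall within the scatter; the estimated step of a 1.3-fold higher number from compound 3 to compound 4 (0.12 log units; within the scatter) reflects that. Compound 4 is expected to give about 85000 nM in this assay, within a range of 30000 nM to 220000 nM.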

Compound 4, concentration for 50% growth inhibition: 27700 nM
Estimate against measurement, compound 4: 3.1-fold (0.49 log units) above; measured number below the stated range.
By their numbers in this assay, from the lowest: compounds 1, 4 and 2 (each within the scatter of the next); then compound 3.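

In this assay the series now has its first single-place comparisons: a 2.3-fold lower number from compound 3 to compound 4 (0.37 log units; beyond the scatter) is beyond the scatter, so on this aromatic carbon the chloro compound carries the higher number and the hydrogen compound the lower one. Hydrogen in place of bromo, on a different aromatic carbon of the shared core, gives a 1.1-fold lower number from compound 2 to compound 4 (0.03 log units; within the scatter) and stays within the scatter, so the two halogen steps do not read alike in these compounds. Nothing measured here accounts for the difference between these two steps.

On these data alone, whether chloro and bromo would read alike on one and the same carbon remains open. Also open, as far as these compounds go, is whether fluoro, methoxy or an amine on the carbon that holds chloro in compound 3 would track that compound or compound 4.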